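A Chlorophenyl Swap on a Weakly Antiproliferative Core

A few compounds are considered here, and "the series" means these few. Any claim that something is new, unique, unknown or untested is made for them only; others in the source may bear on it.

Measured so far:
Compound 1, `CCCSc1nc(N/N=C(\C)c2ccccc2O)c2nnn(Cc3ccc(O)cc3)c2n1`: 9520 nM
Compound 2, `C#CCSc1nc(N/N=C/c2c(O)ccc3ccccc23)c2nnn(Cc3ccccc3)c2n1`: 8970 nM

Of the compounds shown here, two sharing the same core have been tested in a functional assay on MCF7 cells (Homo sapiens) for antiproliferative activity, read by MTT assay, with a stated time of 72 h; a lower number here means a stronger inhibitor, a higher number a weaker inhibitor. Compound 1 `CCCSc1nc(N/N=C(\C)c2ccccc2O)c2nnn(Cc3ccc(O)cc3)c2n1` gives 9520 nM in this assay, and compound 2 `C#CCSc1nc(N/N=C/c2c(O)ccc3ccccc23)c2nnn(Cc3ccccc3)c2n1` gives 8970 nM. Compound 1 holds the higher of the two numbers, but the gap to compound 2 is within the usual scatter of repeated measurements, so the two are not distinguishable on these data; both are weak inhibitors.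

Compound 3 `CCCSc1nc(N/N=C(\C)c2ccccc2O)c2nnn(Cc3cccc(Cl)c3)c2n1` has not yet been measured. It differs from compound 1 in one place: 3-chlorophenyl in place of 4-hydroxyphenyl on a saturated chain carbon bound to an aromatic nitrogen. For the measured compounds named here, no measured pair shows this particular change, so there is no step to lean on, and compound 2 differs from compound 1 in several places at once, which gives no clean reading either.

With so little to go on, the step in this assay is estimated to be small, expected as a 1.4-fold lower number from compound 1 to compound 3 (0.13 log units; within the scatter). Compound 3 is therefore expected near 7000 nM, with a range from 2500 nM to 20000 nM.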

Compound 3, half-maximal inhibitory concentration: 39900 nM
Estimate against measurement, compound 3: 5.7-fold (0.76 log units) below, and the stated range ends below it.
By their numbers in this assay, from the lowest: compounds 2 and 1 (each within the scatter of the next); then compound 3.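

In this assay, the group on a saturated chain carbon bound to an aromatic nitrogen proves to matter: placing 3-chlorophenyl there in place of 4-hydroxyphenyl gives a 4.2-fold higher number from compound 1 to compound 3 (0.62 log units; beyond the scatter) and so leaves the compound weaker. For the compounds shown here, compound 1 and compound 2 differ in several places at once, so only this single-place pair can isolate the effect of this position. The swap replaces a ring carrying one hydrogen-bond donor and one hydrogen-bond acceptor with a ring carrying neither, while also changing where the ring is substituted, and nothing measured here explains the drop or shows which part of the swap matters.

The compounds shown leave open whether the hydroxyl, the chlorine or the substitution site drives this step, a question that 4-chlorophenyl and 3-hydroxyphenyl in the same place could help to separate. They also leave open whether any group here can move the core well past the level of compound 1, such as a 4-aminophenyl or a ring bearing a carboxylic acid.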